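A few compounds are considered here, and "the series" means these few. Any claim that something is new, unique, unknown or untested is made for them only; others in the source may bear on it.

Measured compounds:
- compound 1, `COc1cc2nc(N3CCC(N4CCCC4)CC3)nc(N(C)C)c2cc1OC`: < 0%
- compound 2, `COc1cc2nc(NCCN3CCCCC3)nc(NC3CCCCCC3)c2cc1OC`: 1%
- compound 3, `COc1cc2nc(NCCCN3CCCC3=O)nc(NC3CCCCCC3)c2cc1OC`: 8%

The three compounds share a core and were tested in an in vitro functional assay on B300-19 cells for antagonist activity at C-C chemokine receptor type 4 (Homo sapiens), read by GTPgammaS binding, tested at 1 uM; on this read-out lower numbers stand for less inhibition and higher numbers for more inhibition at the one concentration tested (going by the name of the read-out). Compound 1 reaches only a limit of the assay, < 0%, so it gives no number, only a boundary (the limit of < 0% in this assay, at which 1 of the 3 values shown sits). Compound 2 gives 1%, and compound 3 gives 8%. Among the two numbers that are real values, compound 3 carries the higher one, but the gap to compound 2 is small: the one measured step, a number 7 percentage points higher from compound 2 to compound 3 (within the scatter), lies within the scatter, so the two cannot be told apart.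

Compound 4, `COc1cc2nc(NC(C)C)nc(NC3CCCCCC3)c2cc1OC`, has not been measured. It differs from compound 3 in one place: isopropyl in place of 3-(2-oxopyrrolidin-1-yl)propyl on a nitrogen on an aromatic ring. For the measured compounds named here, the only measured step bears on it loosely, since it swaps one chain end for another while here the whole chain is removed, and that step was within the scatter. None of the three compounds shows meaningful inhibition, so compound 4 is expected to stay near that floor, with the step of a number 5 percentage points lower from compound 3 to compound 4 (within the scatter) expected to be small. Compound 4 is estimated at 3%, between -6% and 15%.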

Compound 4, a percentage reported as inhibition, at one concentration (the size of the read-out at that concentration, not a potency): < 0%
Compound 4: no number, only a limit; the forecaster's own chance of this, stated with the estimate: 30%; middle value at least 3 percentage points from the limit.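

Shortening the group on this nitrogen to isopropyl removes the whole 3-(2-oxopyrrolidin-1-yl)propyl chain, with its five-membered ring and carbonyl, yet this assay shows no change that clears the scatter, and because compound 4 sits at a limit, its steps give only floors: a number at least 8 percentage points lower from compound 3 to compound 4 (that floor lies within the scatter). Replacing the 2-(piperidin-1-yl)ethyl chain instead reads the same way, again as a floor, with a number at least 1 percentage points lower from compound 2 to compound 4 (that floor lies within the scatter). Neither chain therefore shows any measurable contribution over a small branched group at this position, and the readings begin to gather at the bottom of the scale: the limit of < 0% in this assay, at which 2 of the 4 values shown sit.

With every reading on this nitrogen series close to that bottom, the compounds shown cannot reveal whether any group at this position can drive inhibition at the single concentration tested. Going by these compounds, whether a benzyl group, or a longer chain ending in a carboxylic acid or a primary amine, would lift inhibition clear of the scatter remains open.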